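Ester chain length and calcium channel inhibition in a dihydropyridine series

A few compounds are considered here, and "the series" means these few. Any claim that something is new, unique, unknown or untested is made for them only; others in the source may bear on it.

Compound 1, `CC1=C(C(=O)OC(C)C)C(c2csc(-c3ccc(Cl)cc3)n2)C(C(=O)OC(C)C)=C(C)N1`: 37200 nM
Compound 2, `CCOC(=O)C1=C(C)NC(C)=C(C(=O)OC(C)C)C1c1csc(-c2ccc(Cl)cc2)n1`: 2550 nM
Compound 3, `COC(=O)C1=C(C)NC(C)=C(C(=O)OCC(C)C)C1c1csc(-c2ccc(Cl)cc2)n1`: 46900 nM

In an assay on isolated protein for antagonist activity at Voltage-dependent L-type calcium channel subunit alpha-1C (Cavia porcellus), with a stated time of 15 min (on this read-out higher numbers stand for weaker inhibition and lower numbers for stronger inhibition), compound 2 gives 2550 nM. Compound 1 differs by methyl in place of hydrogen on a saturated chain carbon bound to an oxygen next to a carbonyl group and a saturated chain carbon, and this gives a 15-fold higher number from compound 2 to compound 1 (1.16 log units; beyond the scatter). Compound 3 has the same atoms as compound 2 joined differently; the difference between the two cores is not broken down here, and compound 3 gives 46900 nM, within the scatter of compound 1.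

Compound 4, `CCOC(=O)C1=C(C)NC(C)=C(C(=O)OCC(C)C)C1c1csc(-c2ccc(Cl)cc2)n1`, has not been measured. It differs from compound 3 by methyl in place of hydrogen on a saturated chain carbon bound to an oxygen next to a carbonyl group. Within the data shown here, this is the same kind of change as the one from compound 2 to compound 1, but the place differs: there the carbon was also bound to a saturated chain carbon, here it is not. Compound 3 is weak and compound 2, which also carries an ethyl on that ester, is the strongest shown, so the expectation rests on these two pulling in opposite ways. The step from compound 3 to compound 4 is expected to be a 1.9-fold lower number from compound 3 to compound 4 (0.27 log units; within the scatter), and compound 4 is estimated at 25000 nM, between 5000 nM and 90000 nM.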

Compound 4, half-maximal inhibitory concentration: 15400 nM
Compound 4: middle estimate off by 1.6-fold (0.21 log units), on the high side; the measured number falls inside the stated range.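

In this assay, methyl in place of hydrogen on a saturated chain carbon bound to an oxygen next to a carbonyl group gives a 3.0-fold lower number from compound 3 to compound 4 (0.48 log units; beyond the scatter), so the change does not carry over from the earlier pair, where it went the other way: the same change on two cores in this assay, a 15-fold higher number (1.16 log units; beyond the scatter) from compound 2 to compound 1 and a 3.0-fold lower number (0.48 log units; beyond the scatter) from compound 3 to compound 4, 44-fold (1.65 log units) apart, beyond the scatter of two such steps

With the ethyl ester held, isobutyl in place of isopropyl on an oxygen next to a carbonyl group gives a 6.0-fold higher number from compound 2 to compound 4 (0.78 log units; beyond the scatter). The size and direction of the methyl step thus depend on the core in these two pairs, but two pairs give no rule for other cores and do not show why they differ.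

The compounds shown leave open how a longer chain, such as butyl, on either ester would read in this assay. They also leave open what an amine at the end of that chain would do.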